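The source may hold more compounds than are shown below. What is called first, only, known or untested is meant among the compounds shown, and "the series" means these compounds.

Compound 3 `CC(C)OC(=O)N1CCN(C(=O)c2nc(Nc3cc(C4CC4)[nH]n3)c3cc(Cl)ccc3n2)C[C@H]1C` gives 78.5% in an ADME assay on a cell-free system (plasma, Homo sapiens), read by HPLC, with a stated time of 120 min, at 37 degrees C; on this read-out higher numbers stand for a more stable compound and lower numbers for a less stable compound; compound 1 `CCOC(=O)N1CCN(C(=O)c2nc(Nc3cc(C4CC4)[nH]n3)c3cc(Cl)ccc3n2)C[C@H]1C` gives 85.3% and compound 2 `CC(OC(=O)C(C)C)OC(=O)N1CCN(C(=O)c2nc(Nc3cc(C4CC4)[nH]n3)c3cc(Cl)ccc3n2)C[C@H]1C` gives 17.4%, so compound 3 sits close to compound 1 and well clear of compound 2, the step of a number 61.1 percentage points higher from compound 2 to compound 3 (beyond the scatter) being large while a number 6.8 percentage points lower from compound 1 to compound 3 (within the scatter) stays within the scatter. Compound 4 `C[C@@H]1CN(C(=O)c2nc(Nc3cc(C4CC4)[nH]n3)c3cc(Cl)ccc3n2)CCN1C(=O)OCC(Cl)(Cl)Cl` has not been measured; it differs from compound 3 by 2,2,2-trichloroethyl in place of isopropyl on an oxygen next to a carbonyl group. Going by the values given here, no measured step alters the group on that oxygen apart from a number 6.8 percentage points lower from compound 1 to compound 3 (within the scatter), which was small; the large steps of a number 67.9 percentage points lower from compound 1 to compound 2 (beyond the scatter) and a number 61.1 percentage points higher from compound 2 to compound 3 (beyond the scatter) concern the (isopropylcarbonyl)oxy group and do not bear on this exchange. For compound 4 a step of about a number 8.5 percentage points lower from compound 3 to compound 4 (within the scatter) in this assay is therefore expected, modest in either direction. Compound 4 is estimated at 70%, range 45% to 90%.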

Compound 4, percent of the compound remaining: 79%
Beside the measured number, compound 4's estimate is 9 percentage points below it, and the stated range covers the measured number.
By their numbers in this assay, from the lowest: compound 2; then compounds 3, 4 and 1 (each within the scatter of the next).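

In this assay, a chlorine-bearing group on the oxygen next to a carbonyl group does not separate from the plain chains: see 2,2,2-trichloroethyl against isopropyl (a number 0.5 percentage points higher from compound 3 to compound 4 (within the scatter)) and trichloromethyl against methyl on the chain carbon (a number 6.3 percentage points lower from compound 1 to compound 4 (within the scatter)). The 1-((isopropylcarbonyl)oxy)ethyl group of compound 2 remains the only one that stands apart (a number 61.6 percentage points higher from compound 2 to compound 4 (beyond the scatter)). No evidence at hand bears on this result.

Open, from the compounds shown here alone, is whether an amine, a carboxylic acid or a longer chain on that oxygen would stay with the plain chains or fall towards compound 2. Also open, going by these compounds, is whether the large steps belong to 1-((isopropylcarbonyl)oxy)ethyl alone or extend to other groups holding a second ester.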